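A few compounds are considered here, and "the series" means these few. Any claim that something is new, unique, unknown or untested is made for them only; others in the source may bear on it.

Compound 1 `CN1CCN(CC(=O)Nc2nc3ccccc3[nH]2)CC1`: 11%
Compound 2 `CCN1CCN(CC(=O)Nc2nc3ccccc3[nH]2)CC1`: 13.3%
Compound 3 `O=C(CN1CCN(c2ccccc2)CC1)Nc1nc2ccccc2[nH]1`: 4.62%

In a functional assay, read by spectrophotometry, with a stated time of 30 min, tested at 5 ug/mL (on this read-out lower numbers stand for a weaker effect and higher numbers for a stronger effect at the one concentration tested), the three numbers lie within the scatter of one another; compound 3 stands at the low end, with the steps of a number 6.4 percentage points lower from compound 1 to compound 3 (within the scatter) and a number 8.7 percentage points lower from compound 2 to compound 3 (within the scatter). Compound 4 `O=C(CN1CCN(c2ccccc2F)CC1)Nc1nc2ccccc2[nH]1` differs from compound 3 by fluoro in place of hydrogen on an aromatic carbon. Among the compounds with values here, no measured step alters a substituent on the phenyl; the two steps that bring in the phenyl, in place of methyl and in place of ethyl, both stayed within the scatter, and the step of a number 2.3 percentage points higher from compound 1 to compound 2 (within the scatter) did likewise. Nothing among these steps points to a shift in this assay beyond the scatter for the change to compound 4. For compound 4 the expected value is 5%, range 0% to 15%. The estimated step is a number 0.4 percentage points higher from compound 3 to compound 4 (within the scatter).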

Compound 4, a percentage reported as activity, at one concentration (the size of the read-out at that concentration, not a potency): 11.6%
Compound 4: middle estimate off by 6.6 percentage points, on the low side; the measured number falls inside the stated range.
By their numbers in this assay, from the lowest: compounds 3, 1, 4 and 2 (each within the scatter of the next).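

In this assay, within the data shown here, the only step that alters a substituent on the phenyl is a number 7 percentage points higher from compound 3 to compound 4 (within the scatter) and shows that fluoro in place of hydrogen on this aromatic carbon, ortho to a large group, stays within the scatter. With 2-fluorophenyl on the ring amine nitrogen, a number 1.7 percentage points lower from compound 2 to compound 4 (within the scatter) and a number 0.6 percentage points higher from compound 1 to compound 4 (within the scatter) also stay within it, so methyl, ethyl, phenyl and 2-fluorophenyl there remain unseparated at this one concentration. Open, on these data alone, is whether chloro, methoxy or an amine on the phenyl would give a step beyond the scatter. No measurement available here bears on the origin of these numbers.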